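Adding a hydroxy group to compound 2

The compounds below may be only part of what the source reports. "The series", "measured", "known", "first", "only" and "open" are said of these compounds alone.

In an ADME assay on L6 cells (Rattus norvegicus) for cytotoxicity (a lower number here means a stronger inhibitor, a higher number a weaker inhibitor), compound 1 `CC(C)NC(=N)c1ccc(-c2cc3cc(C(=N)NC(C)C)ccc3o2)cc1` gives > 198000 nM, which is a limit of the assay. Compound 2 `CC(C)NC(=N)c1cccc(-c2cc3ccc(C(=N)NC(C)C)cc3o2)c1` gives > 200000 nM, which is also a limit and not a number. Among the compounds with values here, compound 2 therefore has no exact value on this read-out, and the series offers no measured step to use as a scale. Compound 3 `CC(C)NC(=N)c1ccc(O)c(-c2cc3ccc(C(=N)NC(C)C)cc3o2)c1` differs from compound 2 by one change: hydroxy in place of hydrogen on an aromatic carbon. This is hydroxy in place of hydrogen on an aromatic carbon, ortho to a large group and para to a group of 6 heavy atoms. A modest move towards a lower number in this assay is expected, and compound 3 may well return only a limit. The estimated change is an at least 1.6-fold lower number from compound 2 to compound 3 (0.22 log units; that floor lies within the scatter). The expected value for compound 3 is 120000 nM, with an estimated range of 25000 nM to 200000 nM.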

Compound 3, half-maximal inhibitory concentration: > 187000 nM
Compound 3: only a limit was reported; the forecaster's own chance of this, stated with the estimate: 55%; middle value at least 1.5-fold (0.19 log units) away from the limit.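

Compound 3 in this assay gives > 187000 nM, which is a limit. Compound 2 gives > 200000 nM, also a limit, so no step can be read between compound 2 and compound 3. The compounds shown leave open whether hydroxy in place of hydrogen on an aromatic carbon changes this read-out at all.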